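Replacing a Methoxyphenyl with a Chlorophenyl on One Chain

The source may hold more compounds than are shown below. What is called first, only, known or untested is meant among the compounds shown, and "the series" means these compounds.

Compound 1 `COc1cccc(/C=C/C(=O)c2c(OC)cc(OC)cc2OC)c1` was tested in a functional assay on MDA-MB-231 cells (Homo sapiens), read by fluorescence and BrdU incorporation, with a stated time of 48 h, tested at 10 uM (on this read-out higher numbers stand for a weaker effect at the one concentration tested and lower numbers for a stronger effect), where compound 1 gives 43%. Within the data shown here, it is the only compound here with a number attached. The related compound 2 `COc1cc(O)c(C(=O)/C=C/c2ccccc2OC)c(OC)c1` came out in this assay as "not active" (no number reported), with no figure given, so no ordering between compound 1 and compound 2 can be drawn from that entry. Compound 3 `COc1cc(OC)c(C(=O)/C=C/c2ccc(Cl)cc2)c(OC)c1` has not yet been measured. It differs from compound 1 in one place: 4-chlorophenyl in place of 3-methoxyphenyl on a double-bonded chain carbon bound to a double-bonded chain carbon. Among the measured compounds shown here, no measured pair shows what such a swap does, so any expectation rests on compound 1 alone and carries wide uncertainty. The step from compound 1 to compound 3 in this assay is expected to be a number 9 percentage points higher from compound 1 to compound 3 (within the scatter), a small shift toward a weaker effect that may not exceed the usual scatter. Compound 3 is estimated to give 52% in this assay, within a range from 22% to 88%.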

Compound 3, a percentage reported as activity, at one concentration (the size of the read-out at that concentration, not a potency): 39%
The estimate for compound 3 lay 13 percentage points above the measured number; the measured number falls inside the stated range.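

In this assay, among these compounds, the swap gives a number 4 percentage points lower from compound 1 to compound 3 (within the scatter), the first measured step at this place on the chain. The 4-chlorophenyl therefore stands in for the 3-methoxyphenyl with no change that can be told from scatter, even though the entering group has a chlorine instead of an oxygen and no hydrogen-bond acceptor. No measurement here offers an explanation for this result.

From the compounds shown here alone, the swap changes both the substituent and where it sits on the ring, so the effect of each alone remains unknown, and the single concentration says nothing about potency. Going by these compounds, it also remains open whether this place would accept a phenyl ring bearing a carboxylic acid or an amine, or a longer chain in place of the ring, as readily.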